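This account rests on a few compounds, and the source may have more. Where it says the series, first, only, none or still open, it means among the compounds named here.

Among the measured compounds shown here, compound 2 `CNc1cccc2c1cnn2-c1ccc(NC(=O)Nc2ccc(Cl)c(C(F)(F)F)c2)cc1` is one of two urea-linked compounds measured so far. In a functional assay on A549 cells (Homo sapiens) for cytotoxicity, read by MTT assay, with a stated time of 72 h (on this read-out higher numbers stand for weaker inhibition and lower numbers for stronger inhibition), compound 2 gives 4900 nM, which is the higher of the two numbers. Its nearest neighbour is compound 1 `O=C(Nc1ccc(-n2ncc3c(C(F)(F)F)cccc32)cc1)Nc1ccc(Cl)c(C(F)(F)F)c1`, which in this assay gives 3000 nM. The two differ at a single aromatic carbon of the fused ring system, and the step of a 1.6-fold higher number from compound 1 to compound 2 (0.21 log units; within the scatter) shows that replacing trifluoromethyl with methylamino at that place left the number essentially unchanged.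

Compound 3 `COc1cccc2c1cnn2-c1ccc(NC(=O)Nc2ccc(Cl)c(C(F)(F)F)c2)cc1` has not yet been tested in this assay. It differs from compound 2 as follows: methoxy in place of methylamino on an aromatic carbon. This is the same place that was varied in the step of a 1.6-fold higher number from compound 1 to compound 2 (0.21 log units; within the scatter), and that step stayed within the scatter, so the small swap from methylamino to methoxy is expected to bring no movement beyond the scatter either, in neither direction.

Compound 3 is therefore expected to give about 4500 nM in this assay, with a plausible range from 2000 nM to 10000 nM. The expected step of a 1.1-fold lower number from compound 2 to compound 3 (0.04 log units; within the scatter) is estimated to remain inside the usual scatter.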

Compound 3, half-maximal inhibitory concentration: 3700 nM
For compound 3 the middle estimate is 1.2-fold (0.09 log units) above the measured one; the range from low to high includes it.
By their numbers in this assay, from the lowest: compounds 1, 3 and 2 (each within the scatter of the next).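

In this assay, swapping methylamino for methoxy on the same aromatic carbon gives a step that stays within the scatter (a 1.3-fold lower number from compound 2 to compound 3 (0.12 log units; within the scatter)), even though methylamino brings 1 hydrogen-bond donor and methoxy brings 0 hydrogen-bond donors. Among the compounds shown here, the step from trifluoromethyl to methoxy also stays within the scatter (a 1.2-fold higher number from compound 1 to compound 3 (0.09 log units; within the scatter)), so three different groups at this place now give numbers that cannot be told apart in this cell test, where the earlier pair offered only two groups. Nothing available here explains why the number stays so flat across these groups.

Going by these compounds, these three groups are a small sample, so it remains open whether a carboxylic acid, a primary amine or a longer chain such as butoxy at this place would also stay within the scatter or would finally move the number. The compounds shown also all keep the same shared core and the same urea-linked end, which leaves open whether a change elsewhere in the molecule would matter more than any change at this place.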